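Cinnamoyl Variation on a Shared Core: HeLa Cytotoxicity

The compounds below may be only part of what the source reports. "The series", "measured", "known", "first", "only" and "open" are said of these compounds alone.

Compound 1 `O=C(/C=C\c1ccccc1[N+](=O)[O-])N1N=C(c2ccncc2)OC1c1c[nH]c2ccccc12` gives in an ADME assay on HeLa cells (Homo sapiens) for cytotoxicity, read by MTT assay, with a stated time of 72 h (a lower number here means a stronger inhibitor of growth, a higher number a weaker inhibitor of growth), only the assay limit > 30 ug/mL.
Compound 2 `Cc1ccc(/C=C\C(=O)N2N=C(c3ccncc3)OC2c2c[nH]c3ccccc23)cc1` gives in this assay only the limit > 30 ug/mL.
Compound 3 `O=C(/C=C\c1ccc(F)cc1)N1N=C(c2ccncc2)OC1c1c[nH]c2ccccc12` gives in this assay only the limit > 30 ug/mL.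

Compound 3 thus stands at the limit, where the two other values shown also sit (the limit of > 30 ug/mL in this assay, at which 3 of the 3 values shown sit). Compound 4 `O=C(/C=C/c1c(Cl)cccc1Cl)N1N=C(c2ccncc2)OC1c1c[nH]c2ccccc12` differs from it by 2-(2,6-dichlorophenyl)ethenyl in place of 2-(4-fluorophenyl)ethenyl on a carbonyl carbon. Within the data shown here, the steps that bear on this change, a step that the two limits leave unreadable from compound 1 to compound 3 and a step that the two limits leave unreadable from compound 2 to compound 3, are unreadable, as is a step that the two limits leave unreadable from compound 1 to compound 2. No step beyond the scatter can be read from these limits, and the expectation for compound 4 is that it too reaches only the limit of this assay. Compound 4 is estimated at 40 ug/mL, with a range from 15 ug/mL to 150 ug/mL. The expected step that the limit leaves unreadable from compound 3 to compound 4 is accordingly within the scatter.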

Compound 4, concentration for 50% growth inhibition: > 30 ug/mL
Compound 4 gave a limit, no number (the forecaster's own chance of this, stated with the estimate: 75%); the middle value lies beyond the limit too.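

Compound 4, like compound 1, compound 2 and compound 3, gives only a limit in this assay, so no step among them can be read: the limit of > 30 ug/mL in this assay, at which 4 of the 4 values shown sit.

Going by these compounds, whether the groups on the carbonyl carbon differ at all in growth inhibition remains open.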